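Swapping Trifluoromethyl for Methyl on a Sulfur-Linked Side Group

The compounds below may be only part of what the source reports. "The series", "measured", "known", "first", "only" and "open" are said of these compounds alone.

The compounds here share one core and differ in the group attached through sulfur. Compound 1 `Cc1cc(=O)oc2cc(Sc3cccc(Cl)[n+]3[O-])ccc12` and compound 2 `Cc1cc(=O)oc2cc(Sc3cccc(Cl)n3)ccc12` carry the same chlorine-bearing aromatic ring, with compound 1 holding it as an oxide. Compound 3 `Cc1cc(=O)oc2cc(SCc3cccc(C(F)(F)F)c3)ccc12` instead carries a benzyl group bearing trifluoromethyl. In a functional assay on DU-145 cells (Homo sapiens) for antiproliferative activity, read by sulforhodamine B assay, with a stated time of 72 h (on this read-out lower numbers stand for stronger inhibition of growth and higher numbers for weaker inhibition of growth), compound 2 gives 1150 nM. For compound 1 the assay reports only a limit, > 31200 nM. Compound 3 likewise reaches only a limit, > 28500 nM, so no actual number for its growth inhibition is known; it sits at the limit of > 28500 nM in this assay, at which 1 of the 3 values shown sits, and one further value among the three is also a limit rather than a number.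

Compound 4 `Cc1cccc(CSc2ccc3c(C)cc(=O)oc3c2)c1` has not yet been measured. It differs from compound 3 in one place: methyl in place of trifluoromethyl on an aromatic carbon. Among the measured compounds shown here, no pair of measured compounds shows this particular change, so its usual size cannot be read from the data. Because compound 3 sits at the limit of > 28500 nM in this assay, at which 1 of the 3 values shown sits, the starting point itself is only a limit. The expectation is a step that the limit leaves unreadable from compound 3 to compound 4, that is, no change beyond the usual scatter. Compound 4 is therefore estimated at 30000 nM, within a range from 8000 nM to 100000 nM.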

Compound 4, concentration for 50% growth inhibition: > 33700 nM
Compound 4: a limit, no number; the forecaster's own chance of this, stated with the estimate: 65%; middle value at least 1.1-fold (0.05 log units) from the limit.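

The step from compound 3 to compound 4 cannot be read, as each of these two compounds is reported only as a limit, with no actual number. The compounds shown leave open how strongly compound 3 and compound 4 inhibit growth, and whether methyl in place of trifluoromethyl changes that inhibition at all.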